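A few compounds are considered here, and "the series" means these few. Any claim that something is new, unique, unknown or untested is made for them only; others in the source may bear on it.

Compound 1 `O=C(Nc1ccc(Br)cc1)Nc1ccc(Nc2ncnc3c2OCCN3)cc1` and compound 2 `Cc1cc(C)cc(NC(=O)Nc2ccc(Nc3ncnc4c3OCCN4)cc2)c1` share a core that compound 3 `CC(C)(C)c1csc(NC(=O)Nc2ccc(Nc3ncnc4c3OCCN4)cc2)n1` keeps. In an assay on isolated protein for inhibition of proto-oncogene tyrosine-protein kinase receptor Ret variant V804L (Homo sapiens), read by 33P incorporation, with stated times of 15 min and 40 min (a higher number here means a weaker inhibitor, a lower number a stronger inhibitor), compound 1 reaches only > 10000 nM, a limit of the assay and not a number, sitting at the limit of > 10000 nM in this assay, at which 1 of the 2 values shown sits. Compound 2 gives 3770 nM in this assay, a step of an at least 2.6-fold lower number from compound 1 to compound 2 (0.42 log units; beyond the scatter). The change to compound 3 is 4-(tert-butyl)-1,3-thiazol-2-yl in place of 4-bromophenyl on an amide-type nitrogen. Going by the values given here, the one measured step shows that replacing the same group lowers the number, so a downward step of at least modest size is expected, namely an at least 3.3-fold lower number from compound 1 to compound 3 (0.52 log units; beyond the scatter). Compound 3 is therefore estimated at 3000 nM, between 500 nM and 20000 nM.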

Compound 3, half-maximal inhibitory concentration: > 10000 nM
Compound 3: no number, only a limit; the forecaster's own chance of this, stated with the estimate: 30%; at least 3.3-fold (0.52 log units) between middle value and limit.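

Putting 4-(tert-butyl)-1,3-thiazol-2-yl in place of 3,5-dimethylphenyl on an amide-type nitrogen gives a clear change (an at least 2.6-fold higher number from compound 2 to compound 3 (0.42 log units; beyond the scatter)), so in this assay the replacements of 4-bromophenyl do not behave alike, and among the three compounds only compound 2 has a measured number. The step from compound 1 to compound 3 cannot be read because both values are limits of the assay: the limit of > 10000 nM in this assay, at which 2 of the 3 values shown sit.

On these data alone, it remains open whether 1,3-thiazol-2-yl carrying methyl instead of tert-butyl, or a phenyl ring carrying an amine, would give a measurable number.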